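Two methyl groups on a weak five-membered ring amide

The source may report more compounds than this note shows. Statements on the series, on what has been measured and on what is new or still open speak of the compounds shown alone.

Three amides sharing one core have been measured in an assay on isolated protein for inhibition of phosphodiesterase 4A (Sus scrofa); on this read-out higher numbers stand for weaker inhibition and lower numbers for stronger inhibition. Compound 1 `COc1ccc(C(=O)Nc2ccccc2Cl)cc1OC1CCCC1` gives 190 nM, and compound 2 `COc1ccc(C(=O)Nc2c(C)cccc2Cl)cc1OC1CCCC1` gives 100 nM; the step of a 1.9-fold lower number from compound 1 to compound 2 (0.28 log units; within the scatter) shows that one added methyl changes little. Compound 3 `COc1ccc(C(=O)Nc2nccs2)cc1OC1CCCC1`, in which a five-membered ring carrying two hetero atoms replaces the chlorinated benzene ring, gives 6500 nM, the weakest inhibition of the three, as the steps of a 34-fold higher number from compound 1 to compound 3 (1.53 log units; beyond the scatter) and a 65-fold higher number from compound 2 to compound 3 (1.81 log units; beyond the scatter) show.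

Compound 4 `COc1ccc(C(=O)Nc2c(C)nsc2C)cc1OC1CCCC1` keeps the core of compound 3 and changes only the ring on the amide nitrogen: 3,5-dimethyl-1,2-thiazol-4-yl in place of 1,3-thiazol-2-yl on an amide-type nitrogen. The group that enters is again a five-membered aromatic ring with two hetero atoms, now carrying two methyl groups. The large losses from compound 1 and compound 2 to compound 3 show that this ring strongly influences this assay, while the small step from compound 1 to compound 2 suggests that a methyl alone does little. Compound 4 is therefore expected to remain a weak inhibitor, with a modest gain a 2.6-fold lower number from compound 3 to compound 4 (0.41 log units; beyond the scatter) estimated, giving 2500 nM with a range from 500 nM to 12000 nM.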

Compound 4, half-maximal inhibitory concentration: 500 nM
For compound 4 the middle estimate is 5.0-fold (0.70 log units) above the measured one, and the stated range covers the measured number.
By their numbers in this assay, from the lowest: compounds 2 and 1 (each within the scatter of the next); then compound 4; then compound 3.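

In this assay, the ring on the amide-type nitrogen need not be a benzene ring to give fairly strong inhibition: a five-membered aromatic ring with two hetero atoms can do much better than compound 3 suggested (a 13-fold lower number from compound 3 to compound 4 (1.11 log units; beyond the scatter)). The low activity of compound 3 therefore does not hold for every ring of this kind. A modest gap to the chlorinated benzene amides remains (a 2.6-fold higher number from compound 1 to compound 4 (0.42 log units; beyond the scatter)) and (a 5.0-fold higher number from compound 2 to compound 4 (0.70 log units; beyond the scatter)), so compound 4 narrows the earlier loss without closing it.

Compound 4 differs from compound 3 both in its two methyl groups and in the ring itself, so a 1,2-thiazol-4-yl group with no methyl would be needed to tell these two changes apart. No measurement available here explains the gain.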